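Chloro in place of fluoro in compound 4

The source may hold more compounds than are shown below. What is called first, only, known or untested is meant among the compounds shown, and "the series" means these compounds.

Measured in a physicochemical assay for lipophilicity, using the shake flask method, measured as octanol-water partition, at pH 7.4; a lower number here means a more polar compound, a higher number a more lipophilic compound:
- compound 1 `CC(=O)N[C@@H]1CCC[C@H](C(=O)Nc2cc(-c3cnn4c3CCCC4)c(Cl)cn2)C1`: 3.2
- compound 2 `CC(=O)N[C@@H]1CCC[C@H](C(=O)Nc2cc(-c3cnc(C)n3C)c(Cl)cn2)C1`: 2.2
- compound 3 `CC(=O)N[C@@H]1CCC[C@H](C(=O)Nc2cc(-c3cnn4c3CC(C)(C)C4)c(F)cn2)C1`: 3.3

Compound 3 lies level with compound 1 within the usual scatter, and both stand clearly above compound 2. Compound 4 `CC(=O)N[C@@H]1CCC[C@H](C(=O)Nc2cc(-c3cnn4c3CC(C)(C)C4)c(Cl)cn2)C1` has chloro in place of fluoro on an aromatic carbon. For the measured compounds named here, the only measured step, a number 1.00 log units lower from compound 1 to compound 2 (beyond the scatter), replaces a different group, so its size does not carry over, and no measured pair exchanges these two halogens. Resting on the structural change alone, a small upward move in this assay is expected, a number 0.30 log units higher from compound 3 to compound 4 (within the scatter), close to the scatter. Compound 4 is estimated at 3.6, with an expected range of 3.2 to 3.9.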

Compound 4, distribution coefficient: 3.8
Compound 4: middle estimate off by 0.20 log units, on the low side; the measured number falls inside the stated range.
By their numbers in this assay, from the lowest: compound 2; then compounds 1 and 3 (each within the scatter of the next); then compound 4.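

In this assay chloro in place of fluoro on an aromatic carbon gives a number 0.50 log units higher from compound 3 to compound 4 (beyond the scatter) and is the only halogen exchange shown, so this single atom change alone moves the number beyond the scatter. With chloro held, exchanging the other group on an aromatic carbon gives a number 1.60 log units higher from compound 2 to compound 4 (beyond the scatter) and a number 0.60 log units higher from compound 1 to compound 4 (beyond the scatter) and leaves compound 4 the highest of the set.

As far as these compounds go, whether the halogen step holds with the other two groups remains open, as does how bromo or methoxy would read at this position. Nothing available explains these steps.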